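The source may hold more compounds than are shown below. What is called first, only, known or untested is meant among the compounds shown, and "the series" means these compounds.

Compound 1, `COc1cc2ncnc(Nc3ccc(F)cc3)c2cc1OCCCCC(=O)Nc1ccc(S(N)(=O)=O)cc1`. In a functional assay on NCI-H1975 cells (Homo sapiens) for antiproliferative activity, read by MTT assay, with a stated time of 72 h (on this read-out higher numbers stand for weaker inhibition and lower numbers for stronger inhibition), compound 1 gives > 40000 nM, which is a limit of the assay and not a number (the limit of > 40000 nM in this assay, at which 1 of the 3 values shown sits).
Compound 2, `COc1ccc(Nc2ncnc3cc(OC)c(OCCCCC(=O)Nc4ccc(S(N)(=O)=O)cc4)cc23)cc1OC`. In this assay compound 2 gives 9230 nM.
Compound 3, `NS(=O)(=O)c1ccc(NC(=S)Nc2ccc3ncnc(Nc4ccc(F)c(Cl)c4)c3c2)cc1`. In this assay compound 3 gives 15800 nM.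

Among the compounds with values here, compound 3 is one of only two compounds with a number in this assay, and its number and that of compound 2 lie within the usual scatter of each other, so no order between them can be read. Within the data shown here, the only measured step is an at least 4.3-fold lower number from compound 1 to compound 2 (0.63 log units; beyond the scatter), which changed the aryl group on the amine nitrogen on a different core and linker from those of compound 3.

Compound 4, `NS(=O)(=O)c1ccc(NC(=S)Nc2ccc3ncnc(Nc4ccc(Cl)c(C(F)(F)F)c4)c3c2)cc1`, keeps the whole of compound 3 except (4-chloro-3-(trifluoromethyl)phenyl in place of 3-chloro-4-fluorophenyl on a nitrogen on an aromatic ring). Among the measured compounds shown here, no measured pair reports this particular exchange; the step from compound 1 to compound 2 shows only that the aryl group on this nitrogen can move the number, not in which direction a chloro and trifluoromethyl pattern would do so. Compound 4 is therefore expected to stay close to compound 3, with a 1.3-fold lower number from compound 3 to compound 4 (0.12 log units; within the scatter). The estimate for compound 4 in this assay is 12000 nM, within the range 4000 nM to 40000 nM.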

Compound 4, half-maximal inhibitory concentration: 11800 nM
Beside the measured number, compound 4's estimate is 1.0-fold (0.01 log units) above it; low and high end bracket the measured number.
By their numbers in this assay, from the lowest: compounds 2, 4 and 3 (each within the scatter of the next). At a limit, above all of these: compound 1.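

On compound 3's core, the aryl group on the nitrogen was exchanged for one of 11 heavy atoms instead of 8, and in this assay this gave a 1.3-fold lower number from compound 3 to compound 4 (0.13 log units; within the scatter), so the two aryl groups cannot be told apart on this read-out. The earlier step at this place, an at least 4.3-fold lower number from compound 1 to compound 2 (0.63 log units; beyond the scatter), lay beyond the scatter, but it was measured on another core and linker with a different pair of aryl groups; the new step shows that not every exchange here separates two compounds, and that the larger 4-chloro-3-(trifluoromethyl)phenyl group is accepted on this core without a change that can be read. Nothing measured here gives a cause for how this exchange behaves.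

Still open, from the compounds shown here alone, is whether 3,4-dimethoxyphenyl on this nitrogen of compound 3's core would give a step beyond the scatter, as it did on the core of compound 1. Also open, going by these compounds, is how the number would respond if a carboxylic acid took the place of the sulfonamide, or if a nitrile or an amine were carried on the aryl ring.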